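Extending the Carbonyl Link in Compound 3

The source may report more compounds than this note shows. Statements on the series, on what has been measured and on what is new or still open speak of the compounds shown alone.

Compound 2 `COc1cc(-c2nn(-c3cccc(NC(=O)c4ccc(Cl)c(C(F)(F)F)c4)c3)cc2-c2ccncc2)ccc1Cl` gives 8040 nM in a functional assay on OVCAR-4 cells (Homo sapiens) for inhibition, read by sulforhodamine B assay, with a stated time of 48 h (on this read-out lower numbers stand for stronger inhibition of growth and higher numbers for weaker inhibition of growth), the highest of the two numbers recorded so far. Compound 1 `COc1cc(-c2nn(-c3cccc(NC(=O)c4cccc(C(F)(F)F)c4)c3)cc2-c2ccncc2)ccc1Cl` gives 2280 nM in this assay, and the step of a 3.5-fold higher number from compound 1 to compound 2 (0.55 log units; beyond the scatter) comes from chloro in place of hydrogen on an aromatic carbon. Compound 3 `COc1cc(-c2nn(-c3cccc(NC(=O)Nc4ccc(Cl)c(C(F)(F)F)c4)c3)cc2-c2ccncc2)ccc1Cl` differs from compound 2 by (4-chloro-3-(trifluoromethyl)phenyl)amino in place of 4-chloro-3-(trifluoromethyl)phenyl on a carbonyl carbon. Within the data shown here, no measured step bears on this change: the only step recorded, a 3.5-fold higher number from compound 1 to compound 2 (0.55 log units; beyond the scatter), concerns the chloro on the aromatic ring and leaves the carbonyl carbon untouched. With nothing more to go on, the expectation for this assay is a change of uncertain direction, most likely within the scatter or a little beyond it. Compound 3 is therefore estimated at 5000 nM, within 1200 nM to 20000 nM, an expected step of a 1.6-fold lower number from compound 2 to compound 3 (0.21 log units; within the scatter).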

Compound 3, concentration for 50% growth inhibition: 1290 nM
Beside the measured number, compound 3's estimate is 3.9-fold (0.59 log units) above it; the range from low to high includes it.
By their numbers in this assay, from the lowest: compounds 3 and 1 (each within the scatter of the next); then compound 2.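

In this assay the carbonyl carbon proves to be a place where the change counts: (4-chloro-3-(trifluoromethyl)phenyl)amino in place of 4-chloro-3-(trifluoromethyl)phenyl gives a 6.2-fold lower number from compound 2 to compound 3 (0.79 log units; beyond the scatter) and so more than reverses the earlier loss seen on adding the chloro. Set against the compound without that chloro, the same group in place of 3-(trifluoromethyl)phenyl gives a 1.8-fold lower number from compound 1 to compound 3 (0.25 log units; within the scatter) and so leaves compound 3 within the scatter of compound 1. Nothing measured here accounts for this shift.

Going by these compounds, whether the chloro still lowers growth inhibition once the amino link is present stays open, since the effects of the two changes cannot be separated without the amino compound that carries 3-(trifluoromethyl)phenyl alone. Also open, on these data alone, is whether a methylene or an ether oxygen in place of the amino nitrogen would serve in the same way.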